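The source may report more compounds than this note shows. Statements on the series, on what has been measured and on what is new or still open speak of the compounds shown alone.

Measured so far:
- compound 1, `COc1cc2nc(N3CCN(S(=O)(=O)c4ccc(OC(F)(F)F)cc4)CC3)nc(N)c2cc1OC`, 25000 nM in a functional assay on PC-3 cells (Homo sapiens) for inhibition; a lower number here means a stronger inhibitor, a higher number a weaker inhibitor
- compound 2, `COc1cc2nc(N3CCN(S(=O)(=O)c4cccc(C(=O)O)c4)CC3)nc(N)c2cc1OC`, 53000 nM
- compound 3, `COc1cc2nc(N3CCN(S(=O)(=O)c4cc(Cl)ccc4Cl)CC3)nc(N)c2cc1OC`, 60000 nM

Compound 3 carries the highest number of the three in this assay. Against compound 2 the gap is a 1.1-fold higher number from compound 2 to compound 3 (0.05 log units; within the scatter), so the two stand together; against compound 1 it is a 2.4-fold higher number from compound 1 to compound 3 (0.38 log units; beyond the scatter), a modest but real loss. The whole series sits at weak inhibition, and the three sulfonyl aryl groups tried so far move the number only a little.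

The next step is to compound 4, `COc1cc2nc(N3CCN(S(=O)(=O)c4ccc(-c5ccccc5)cc4)CC3)nc(N)c2cc1OC`. The change is 4-phenylphenyl in place of 2,5-dichlorophenyl on a sulfonyl sulfur. Among the compounds with values here, no measured step bears on a 4-phenylphenyl group directly. The steps that touch the same position, a 2.4-fold higher number from compound 1 to compound 3 (0.38 log units; beyond the scatter) and a 1.1-fold higher number from compound 2 to compound 3 (0.05 log units; within the scatter), show that swapping one aryl group for another at the sulfonyl sulfur has shifted the result only modestly or not beyond the scatter. The expectation for compound 4 is therefore a step of about a 1.5-fold lower number from compound 3 to compound 4 (0.18 log units; within the scatter) in this assay, that is no clear change beyond the scatter, with a slight lean toward a lower number given that compound 3 already holds the highest value. Compound 4 is estimated at 40000 nM, within a range from 15000 nM to 110000 nM.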

Compound 4, half-maximal inhibitory concentration: 4200 nM
Compound 4: middle estimate off by 9.5-fold (0.98 log units), on the high side; the measured number lies below the stated range.
By their numbers in this assay, from the lowest: compound 4; then compound 1; then compounds 2 and 3 (each within the scatter of the next).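

In this assay the aryl group on the sulfonyl sulfur, which had moved the number only a little across compounds 1, 2 and 3, turns out to allow a much larger gain: 4-phenylphenyl gives a 14-fold lower number from compound 3 to compound 4 (1.15 log units; beyond the scatter) and a 13-fold lower number from compound 2 to compound 4 (1.10 log units; beyond the scatter). Even against compound 1, the lowest of the earlier numbers, phenyl in place of trifluoromethoxy on an aromatic carbon gives a 6.0-fold lower number from compound 1 to compound 4 (0.77 log units; beyond the scatter), which leaves compound 4 with the lowest number of the four and beyond the scatter of each of the others. Nothing among the available data accounts for this gain.

The compounds shown leave open whether the added ring has to be an all-carbon phenyl, or whether a pyridyl ring, a benzyloxy group or a longer alkyl chain in its place would hold the lower number. They also leave open whether an amine or a carboxylic acid on the added phenyl ring would keep the gain seen with compound 4.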